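Cytotoxicity notes: methylsulfanyl for methyl on the shared core

The source may report more compounds than this note shows. Statements on the series, on what has been measured and on what is new or still open speak of the compounds shown alone.

Measured so far in a functional assay on MT2 cells (Homo sapiens) for cytotoxicity; on this read-out higher numbers stand for lower toxicity in this test and lower numbers for higher toxicity in this test:
compound 1 `CC(C)=CCOc1cc(Nc2nccc(C)n2)ccc1Cl` gives a limit of < 200 nM
compound 2 `CC(C)=CCOc1cccc(Nc2nccs2)c1` gives 23000 nM
compound 3 `COc1ccc(Nc2nccs2)cc1OCC=C(C)C` gives 42000 nM

The result for compound 1 is a limit of the assay and not a number, and it sits at the limit of < 200 nM in this assay, at which 1 of the 3 values shown sits. Within the data shown here, the only measured step, a 1.8-fold higher number from compound 2 to compound 3 (0.26 log units; within the scatter), concerns methoxy in place of hydrogen on an aromatic carbon and stays within the scatter; it does not touch the change considered here.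

Compound 4 `CSc1ccnc(Nc2ccc(Cl)c(OCC=C(C)C)c2)n1` differs from compound 1 by methylsulfanyl in place of methyl on an aromatic carbon. Among the measured compounds shown here, no measured step bears on methylsulfanyl in place of methyl, so in this assay no shift beyond the scatter is expected, and a limit again seems as likely as a number. Compound 4 is expected to give 200 nM, in the range 60 nM to 700 nM. The expected step is a number no lower from compound 1 to compound 4 (the limit leaves the size open).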

Compound 4, half-maximal cytotoxic concentration: 2800 nM
Estimate against measurement, compound 4: 14-fold (1.15 log units) below; the whole stated range lies below it.
By their numbers in this assay, from the lowest: compound 4; then compounds 2 and 3 (each within the scatter of the next). At a limit, below all of these: compound 1.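

In this assay, methylsulfanyl in place of methyl on this aromatic carbon gives an at least 14-fold higher number from compound 1 to compound 4 (1.14 log units; beyond the scatter). Among these compounds, the read-out therefore responds to a change at this position, whereas the only earlier step concerned methoxy at another place and stayed within the scatter. Compound 1 stands at a limit of the assay and not at a number: the limit of < 200 nM in this assay, at which 1 of the 4 values shown sits.

Going by these compounds, the full size of this step stays open. Also open, on these data alone, is what an amine or a longer chain such as ethylsulfanyl would give on this carbon of the shared core.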